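The source may hold more compounds than are shown below. What is called first, only, known or untested is meant among the compounds shown, and "the series" means these compounds.

Compound 1 `COc1cc(-c2nccn2C(C)C)cc(OC)c1OC` carries an isopropyl on the aromatic nitrogen of its five-membered ring. In a functional assay on T47D cells (Homo sapiens) for antiproliferative activity, read by MTT assay, with a stated time of 72 h (a lower number here means a stronger inhibitor, a higher number a weaker inhibitor), compound 1 gives only > 100000 nM, which is a limit of the assay and not a number. Compound 1 thus stands at the limit of > 100000 nM in this assay, at which 1 of the 2 values shown sits. A second measured compound, compound 2 `COc1cc(-c2nccn2-c2ccc3cc[nH]c3c2)cc(OC)c1OC`, bears a different group on that same nitrogen; in this assay compound 2 gives 18000 nM, a real number rather than a limit. The still unmeasured compound 3 `COc1cc(-c2nccn2-c2ccc(Br)cc2)cc(OC)c1OC` differs from compound 1 by 4-bromophenyl in place of isopropyl on an aromatic nitrogen. The change places an aromatic ring where compound 1 had an isopropyl, and compound 2 already shows that an aromatic group on this nitrogen goes with a measurable value of 18000 nM. On that basis the step in this assay is expected to be an at least 4.0-fold lower number from compound 1 to compound 3 (0.60 log units; beyond the scatter), toward stronger inhibition and beyond the usual scatter. Compound 3 is therefore expected to give 25000 nM in this assay. For compound 3 the range of that expectation runs from 6000 nM to 90000 nM, with some chance that only a limit is returned.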

Compound 3, half-maximal inhibitory concentration: 24600 nM
Compound 3: middle estimate off by 1.0-fold (0.01 log units), on the high side, and the stated range covers the measured number.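

In this assay, putting 4-bromophenyl in place of isopropyl on the aromatic nitrogen gives an at least 4.0-fold lower number from compound 1 to compound 3 (0.60 log units; beyond the scatter), so this position now has a direct comparison of two groups differing in one place, which the two earlier compounds did not offer. Compound 3 also adds a second aromatic group on this nitrogen that returns a real number, and its group holds one six-membered aromatic ring of carbon only, a different group from that of compound 2. Compound 1 remains a limit of the assay, so the step gives only a minimum size and its true size cannot be read: the limit of > 100000 nM in this assay, at which 1 of the 3 values shown sits.

The compounds shown leave open what a plain phenyl, a phenyl carrying an amine or a carboxylic acid, or a longer chain in place of isopropyl would give on this nitrogen, and so whether the bromine plays any part in the step. Also open, on these data alone, is whether any group here can bring the number well under those of compound 2 at 18000 nM and compound 3 at 24600 nM.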